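Phenoxy for 3-Methoxyphenyl at a Solubility Limit

The source may hold more compounds than are shown below. What is called first, only, known or untested is meant among the compounds shown, and "the series" means these compounds.

In a physicochemical assay for solubility, read by HPLC, in phosphate buffer, with a stated time of 24 h, at pH 7.4 (a lower number here means a less soluble compound, a higher number a more soluble compound), compound 1 `COc1ccc(Cn2nnc(O)c2C(=O)Nc2cccc(-c3ccc(O)cc3)c2)cc1` gives 2050 nM. Compound 2 `COc1ccc(Cn2nnc(O)c2C(=O)Nc2cccc(-c3ccc(OC)cc3)c2)cc1` returns only a limit, < 1000 nM. Compound 3 `COc1ccc(Cn2nnc(O)c2C(=O)Nc2cccc(-c3cccc(OC)c3)c2)cc1` also returns only a limit, < 1000 nM. Compound 3 therefore has no exact number and sits at the limit of < 1000 nM in this assay, at which 2 of the 3 values shown sit.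

Compound 4 `COc1ccc(Cn2nnc(O)c2C(=O)Nc2cccc(Oc3ccccc3)c2)cc1` keeps the shared core but carries phenoxy in place of 3-methoxyphenyl on an aromatic carbon.

Two measured steps can be read in part. One is an at least 2.0-fold lower number from compound 1 to compound 2 (0.31 log units; beyond the scatter), and the other is an at least 2.0-fold lower number from compound 1 to compound 3 (0.31 log units; beyond the scatter). Going by the values given here, both start from compound 1, the only compound with the 4-hydroxyphenyl group and the only one with an exact number. Among the compounds with values here, neither step measures a swap like the one in compound 4. The closest comparison is a step that the two limits leave unreadable from compound 2 to compound 3, which gives no size to carry over.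

With no readable step between two compounds lacking that 4-hydroxyphenyl group, no clear direction can be predicted. The expected change is a step that the limit leaves unreadable from compound 3 to compound 4, with nothing expected beyond the scatter. Compound 4 is estimated at 700 nM, with an expected range from 250 nM to 1800 nM, and it may well return only a limit.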

Compound 4, solubility: < 1000 nM
Compound 4 was reported as a limit; the forecaster's own chance of this, stated with the estimate: 65%; the middle value does not contradict the limit.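

In this assay compound 4 gives < 1000 nM as a limit of the assay and not a number. Phenoxy in place of 4-hydroxyphenyl gives an at least 2.0-fold lower number from compound 1 to compound 4 (0.31 log units; beyond the scatter) and so adds a third compound that stands apart from compound 1, now with a group whose ring differs from the earlier ones in how it is attached to the aromatic carbon. The steps among compounds 2, 3 and 4 cannot be read, so this position shows no order among the three groups, and the cluster at the assay's limit has grown: the limit of < 1000 nM in this assay, at which 3 of the 4 values shown sit.

Going by these compounds, how phenoxy truly compares with 3-methoxyphenyl or 4-methoxyphenyl stays open, since none of the three compounds has an exact number here. Also open, on these data alone, is whether a group such as an amine or a carboxylic acid in place of phenoxy would return an exact number like compound 1, or whether a hydroxy group added to phenoxy would do the same.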